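Aryl swap at the double-bonded chain of compound 1

The source may hold more compounds than are shown below. What is called first, only, known or untested is meant among the compounds shown, and "the series" means these compounds.

Compound 1 `COc1ccc(C(=O)c2cc(OC)c(OC)c(OC)c2)cc1NC(=O)/C=C/c1cc(OC)c(OC)c(OC)c1` belongs to a set of three compounds on the shared core that differ only in the aryl group on a double-bonded chain carbon bound to a double-bonded chain carbon. In a functional assay on PC-3 cells (Homo sapiens) for cytotoxicity, read by MTT assay, with a stated time of 72 h (on this read-out lower numbers stand for stronger inhibition and higher numbers for weaker inhibition), compound 1 gives 3900 nM, the second highest of the three numbers. Compound 2 `COc1cccc(/C=C/C(=O)Nc2cc(C(=O)c3cc(OC)c(OC)c(OC)c3)ccc2OC)c1` gives 4700 nM in this assay. Compound 3 `COc1ccc(C(=O)c2cc(OC)c(OC)c(OC)c2)cc1NC(=O)/C=C/c1ccc(F)cc1` gives 3200 nM in this assay. The steps of a 1.2-fold higher number from compound 1 to compound 2 (0.08 log units; within the scatter) and a 1.2-fold lower number from compound 1 to compound 3 (0.09 log units; within the scatter) both stay within the scatter, and the same holds for a 1.5-fold lower number from compound 2 to compound 3 (0.17 log units; within the scatter), so none of the aryl swaps seen so far moved the number beyond what repeated measurements would show.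

Compound 4 `COc1ccc(C(=O)c2cc(OC)c(OC)c(OC)c2)cc1NC(=O)/C=C/c1ccc(C(F)(F)F)cc1` has not yet been measured in this assay. It differs from compound 1 by 4-(trifluoromethyl)phenyl in place of 3,4,5-trimethoxyphenyl on a double-bonded chain carbon bound to a double-bonded chain carbon. The step from compound 1 to compound 3, which also replaces the trimethoxyphenyl by a para-substituted phenyl bearing fluorine, is the most direct guide, and it stayed within the scatter. On that basis the expected step for compound 4 is a 1.1-fold lower number from compound 1 to compound 4 (0.05 log units; within the scatter), which is no change beyond the scatter. Compound 4 is therefore estimated at 3500 nM in this assay, with a range from 1500 nM to 8000 nM.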

Compound 4, half-maximal inhibitory concentration: 3500 nM
Estimate against measurement, compound 4: no gap at the digits printed; measured number inside the range.
By their numbers in this assay, from the lowest: compounds 3, 4, 1 and 2 (each within the scatter of the next).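

In this assay, replacing 3,4,5-trimethoxyphenyl with 4-(trifluoromethyl)phenyl gives a 1.1-fold lower number from compound 1 to compound 4 (0.05 log units; within the scatter), so at this position an aryl group without hydrogen-bond acceptors and with fewer heavy atoms reads the same as one that carries acceptors, within the scatter. The change on the aromatic carbon itself, trifluoromethyl in place of fluoro, gives a 1.1-fold higher number from compound 3 to compound 4 (0.04 log units; within the scatter), and the comparison with the other methoxy-bearing aryl group gives a 1.3-fold lower number from compound 2 to compound 4 (0.13 log units; within the scatter); the position therefore stays flat both for a whole aryl swap and for a change of a single substituent on the ring. Nothing measured here accounts for this lack of response at the position.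

The four compounds shown carry only methoxy, fluoro or trifluoromethyl on this aryl group, so it remains open whether an amine or a carboxylic acid on the same ring would move the number beyond the scatter. Also open, as far as these compounds go, is whether any change at this position matters at all, or whether the numbers in this assay are set by the shared core, which stays the same in all four compounds.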